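Swapping Methoxy for Nitro on an Aromatic Carbon

This account rests on a few compounds, and the source may have more. Where it says the series, first, only, none or still open, it means among the compounds named here.

- Compound 1 (`COc1cc(OC)c(C(=O)/C=C/c2ccc(O)cc2)c(OC)c1`) gives 40600 nM
- Compound 2 (`COc1cc(OC)c(C(=O)/C=C/c2ccccc2OC)c(OC)c1`) gives 19600 nM
- Compound 3 (`COc1cc(OC)c(C(=O)/C=C/c2ccc(Cl)cc2)c(OC)c1`) gives 3900 nM

In a functional assay on HeLa cells (Homo sapiens) for inhibition, read by MTT assay, with a stated time of 72 h (a higher number here means a weaker inhibitor, a lower number a stronger inhibitor), compound 2 holds the middle place of the three, with compound 1 higher and compound 3 lower. Compound 4 (`COc1cc(OC)c(C(=O)/C=C/c2ccccc2[N+](=O)[O-])c(OC)c1`) differs from compound 2 by nitro in place of methoxy on an aromatic carbon and carries nitro in place of methoxy on an aromatic carbon. Among the measured compounds shown here, no measured compound has nitro there. The nearest evidence is a 2.1-fold lower number from compound 1 to compound 2 (0.32 log units; beyond the scatter) and a 5.0-fold lower number from compound 2 to compound 3 (0.70 log units; beyond the scatter) and a 10-fold lower number from compound 1 to compound 3 (1.02 log units; beyond the scatter) on the same ring, each beyond the scatter. A modest fall in the number is therefore expected, an estimated 2.0-fold lower number from compound 2 to compound 4 (0.29 log units; within the scatter) in this assay with wide uncertainty. Compound 4 is estimated at 10000 nM (3000 nM to 30000 nM).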

Compound 4, half-maximal inhibitory concentration: 9000 nM
Compound 4: middle estimate off by 1.1-fold (0.05 log units), on the high side; measured number inside the range.
By their numbers in this assay, from the lowest: compound 3; then compound 4; then compound 2; then compound 1.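

In this assay, the step at the aromatic carbon ortho to a large group is a 2.2-fold lower number from compound 2 to compound 4 (0.34 log units; beyond the scatter), with nitro in place of methoxy. Unlike the earlier steps, which also moved the group to another place on the ring, this one changes the group alone, so it is the first reading of this single position. Nothing measured here accounts for the fall in the number.

Going by these compounds, whether an amine or a carboxylic acid at this same carbon would lower the number further remains open. So does whether nitro would give a similar step elsewhere on the ring.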